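The source may report more compounds than this note shows. Statements on the series, on what has been measured and on what is new or still open speak of the compounds shown alone.

Compound 1 `Cn1nc(-c2ccnc(Nc3cccc(O)c3)n2)c2ccccc21` and compound 2 `CCn1nc(-c2ccnc(Nc3cccc(O)c3)n2)c2ccccc21` share one core, while compound 3 `Cc1nn(-c2ccnc(Nc3cccc(S(N)(=O)=O)c3)n2)c2ncccc12` and compound 4 `CCc1nn(-c2ccnc(Nc3cccc(S(N)(=O)=O)c3)n2)c2ncccc12` share another; the difference between the two cores is not broken down here. In a functional assay on MCF7 cells (Homo sapiens) for antiproliferative activity, read by MTT assay, with a stated time of 72 h (a higher number here means a weaker inhibitor of growth, a lower number a stronger inhibitor of growth), compound 1 gives 28200 nM. Compound 2 differs from compound 1 in a single place: methyl in place of hydrogen on a saturated chain carbon bound to an aromatic nitrogen In this assay compound 2 gives 33500 nM, and the step is a 1.2-fold higher number from compound 1 to compound 2 (0.07 log units; within the scatter). In this assay compound 3 gives 20000 nM; its number lies within the scatter of both compound 1 and compound 2, so no order among the three is claimed.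

Compound 4 stands to compound 3 much as compound 2 stands to compound 1: methyl in place of hydrogen on a saturated chain carbon bound to an aromatic carbon The two changes are the same kind of change rather than the same, since in compound 2 the saturated chain carbon is bound to an aromatic nitrogen, whereas in compound 4 it is bound to an aromatic carbon. The expectation for compound 4 rests on compound 3 at 20000 nM and on the earlier step of a 1.2-fold higher number from compound 1 to compound 2 (0.07 log units; within the scatter), which stayed within the scatter. In this assay the step is expected to be a 1.2-fold higher number from compound 3 to compound 4 (0.06 log units; within the scatter), of a size beside the earlier one. Compound 4 is therefore estimated at 23000 nM, with a range from 10000 nM to 50000 nM.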

Compound 4, concentration for 50% growth inhibition: 73200 nM
Compound 4: middle estimate off by 3.2-fold (0.50 log units), on the low side, outside the stated range (above it).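

In this assay, methyl in place of hydrogen on a saturated chain carbon bound to an aromatic carbon gives a 3.7-fold higher number from compound 3 to compound 4 (0.56 log units; beyond the scatter), a modest step towards weaker inhibition of growth that lies beyond the scatter. Set beside the earlier step, this shows that the same kind of change, methyl to ethyl, did not carry over from one core to the other with the same size, so a small step on the core of compound 1 was no safe guide to the step on the core of compound 3: the same change on two cores in this assay, a 1.2-fold higher number (0.07 log units; within the scatter) from compound 1 to compound 2 and a 3.7-fold higher number (0.56 log units; beyond the scatter) from compound 3 to compound 4, 3.1-fold (0.49 log units) apart, beyond the scatter of two such steps It does not show what lies behind the gap, whether the core itself or the different place of the chain, and with a single pair on each core it gives no rule for other pairs in this series.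

The compounds shown leave open whether a longer chain such as propyl, in place of the ethyl of compound 4, would take the number further in the same direction on this core. They also leave open how an amine or a carboxylic acid at that place would read in this assay, on either core.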